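Swapping the aryl group on the saturated ring carbon

This account rests on a few compounds, and the source may have more. Where it says the series, first, only, none or still open, it means among the compounds named here.

Measured compounds, each with its result in a functional assay on PC-3 cells (Homo sapiens) for antiproliferative activity, read by MTT assay, tested at 1 uM; on this read-out lower numbers stand for a weaker effect and higher numbers for a stronger effect at the one concentration tested:
- compound 1 `COc1ccc(OC)c(/C=N/NC(=O)c2cc(OC)c(OC)c(OC)c2)c1` gives 30.9%
- compound 2 `COc1ccc(C2OC(c3cc(OC)c(OC)c(OC)c3)=NN2C(C)=O)c(OC)c1` gives 69.5%
- compound 3 `COc1cc(C2=NN(C(C)=O)C(c3c(Cl)cccc3Cl)O2)cc(OC)c1OC` gives 5.1%

Compound 3 stands lowest of the three numbers. Its nearest neighbour is compound 1, which sits well above it; the gap to compound 2 is larger still, and both gaps lie beyond the usual scatter.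

The compound not yet measured is compound 4 `COc1cc(C2=NN(C(C)=O)C(c3ccc(Cl)c([N+](=O)[O-])c3)O2)cc(OC)c1OC`. It differs from compound 3 in one place: 4-chloro-3-nitrophenyl in place of 2,6-dichlorophenyl on a saturated ring carbon.

Among the compounds with values here, only one measured step touches the same position. It is a number 64.4 percentage points lower from compound 2 to compound 3 (beyond the scatter), and it shows that the aryl group on that saturated ring carbon can move the result across most of the scale. Compound 4 does not restore the 2,4-dimethoxyphenyl of compound 2; it carries a different pattern again, so the direction is open. Given how far compound 3 lies below compound 2, a rise from compound 3 seems more likely than a further fall, and the expected step is a number 24.9 percentage points higher from compound 3 to compound 4 (beyond the scatter).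

Compound 4 is therefore estimated at 30%, with a range from 5% to 60%.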

Compound 4, a percentage reported as inhibition, at one concentration (the size of the read-out at that concentration, not a potency): 43.3%
Estimate against measurement, compound 4: 13.3 percentage points below; measured number inside the range.
By their numbers in this assay, from the lowest: compound 3; then compound 1; then compound 4; then compound 2.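

In this assay, putting 4-chloro-3-nitrophenyl in place of 2,6-dichlorophenyl on the saturated ring carbon gives a number 38.2 percentage points higher from compound 3 to compound 4 (beyond the scatter) and shows that an aryl group carrying chlorine need not leave the result as low as in compound 3. Putting the same group in place of 2,4-dimethoxyphenyl gives a number 26.2 percentage points lower from compound 2 to compound 4 (beyond the scatter) and places compound 4 between the other two, so three aryl groups at this one position now give three results that lie clearly apart, rather than just a high one and a low one. The results show how far the number moves with this change, but no measurement shown here explains why these aryl groups differ.

From the compounds shown here alone, the two chlorophenyl groups differ in the number of chlorines, their placement and the nitro group all at once, so the share of each in the step remains unknown. Going by these compounds, it also remains open where a phenyl ring bearing an amine or a carboxylic acid would fall, or a longer alkyl chain with no aromatic ring at all.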